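The compounds below may be only part of what the source reports. "The series", "measured", "known", "first", "only" and "open" are said of these compounds alone.

Measured in a functional assay on HL-60 cells (Homo sapiens) for antiproliferative activity, with a stated time of 24 h; on this read-out higher numbers stand for weaker inhibition and lower numbers for stronger inhibition:

- compound 1, `NC(=O)c1c(NC(=O)c2ccccc2Cl)sc2c1CCN(Cc1ccccc1F)C2`: 21800 nM
- compound 2, `NC(=O)c1c(NC(=O)c2ccccc2Cl)sc2c1CCN(C(=S)Nc1cccc3ccccc13)C2`: 13400 nM
- compound 3, `NC(=O)c1c(NC(=O)c2ccccc2Cl)sc2c1CCN(C(=S)Nc1cc(C(F)(F)F)cc(C(F)(F)F)c1)C2`: 6500 nM

Compound 3 gives the lowest number of the three in this assay. Compound 2 gives a higher number, and the gap lies beyond the usual scatter. Compound 1 gives the highest number, again beyond the scatter from compound 3. On these three values compound 3 is thus the strongest inhibitor of the set. The three compounds differ from one another at the nitrogen of the shared core, and no two of them differ in only one place, so no single change can be isolated among the measured compounds.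

Compound 4, `Cc1ccc(C(=O)Nc2sc3c(c2C(N)=O)CCN(C(=S)Nc2cc(C(F)(F)F)cc(C(F)(F)F)c2)C3)cc1`, keeps the thiourea part of compound 3 and changes the acyl group on the amide-type nitrogen: 4-methylphenyl in place of 2-chlorophenyl on a carbonyl carbon. Going by the values given here, no measured pair shows the effect of this exchange anywhere, so the direction of the step cannot be read from the data. A modest step, possibly within the scatter, is expected in this assay, with the wider uncertainty toward a higher number. Compound 4 is estimated at 8500 nM, within 3000 nM to 25000 nM. This estimate means an expected step of a 1.3-fold higher number from compound 3 to compound 4 (0.12 log units; within the scatter).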

Compound 4, half-maximal inhibitory concentration: 11800 nM
Compound 4: middle estimate off by 1.4-fold (0.14 log units), on the low side; the measured number falls inside the stated range.
By their numbers in this assay, from the lowest: compounds 3, 4, 2 and 1 (each within the scatter of the next, the first and the last beyond it).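

In this assay, going by these compounds alone, the exchange of 2-chlorophenyl for 4-methylphenyl on a carbonyl carbon gives the first step in which only one place differs (a 1.8-fold higher number from compound 3 to compound 4 (0.26 log units; within the scatter)). With the thiourea part of compound 3 held fixed, this position therefore takes either aromatic ring without a difference that can be told apart from the scatter of the assay. Neither the chlorine nor its place on the ring is shown here to be needed for the antiproliferative read-out, although this rests on a single pair of compounds, and nothing in the data available bears on what lies behind the result.

As far as these compounds go, what stays open is whether this position responds at all to groups less like these two rings, such as a pyridine ring, a plain alkyl chain or a ring carrying a carboxylic acid or an amine on the same carbonyl carbon. From the compounds shown here alone, it is also open whether the same exchange gives a comparable step when the nitrogen of the shared core carries the substituent of compound 1 or compound 2 instead of that of compound 3.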